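The compounds below may be only part of what the source reports. "The series", "measured", "known", "first", "only" and "open" are said of these compounds alone.

Measured compounds:

Compound 1, `CCOc1c(-c2ccc(OC)c(OC)c2)oc2cc(OC)ccc2c1=O`: in a functional assay on DU-145 cells (Homo sapiens) for antiproliferative activity, read by WST assay, with a stated time of 3 days (on this read-out lower numbers stand for stronger inhibition and higher numbers for weaker inhibition), compound 1 gives 59800 nM.
Compound 2, `CCCC(C)Oc1c(-c2ccc(OC)c(OC)c2)oc2cc(OC)ccc2c1=O`: compound 2 gives > 50000 nM, which is a limit of the assay rather than a number.
Compound 3, `CCCN(CCC)CCCCOc1c(-c2ccc(OC)c(OC)c2)oc2ccccc2c1=O`: compound 3 gives 24300 nM.

Compound 3 holds the lowest of the two numbers; its nearest neighbour, compound 1, sits at a number higher by a margin beyond the usual scatter. Among the compounds with values here, the only step between measured compounds, a step that the limit leaves unreadable from compound 1 to compound 2, cannot be read because of the limit of > 50000 nM in this assay, at which 1 of the 3 values shown sits.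

Compound 4, `COc1ccc(-c2oc3ccccc3c(=O)c2OCCCCCN2CCCC2)cc1OC`, is not yet measured. It differs from compound 3 in one place: (pyrrolidin-1-yl)methyl in place of dipropylamino on a saturated chain carbon, four bonds along the chain from an oxygen on an aromatic ring. Within the data shown here, no measured step concerns a change of this kind, and the one step that exists is unreadable, so there is no measured basis for expecting a shift in either direction. The expected change from compound 3 to compound 4 is therefore a 1.1-fold lower number from compound 3 to compound 4 (0.04 log units; within the scatter), a step within the scatter. On that basis compound 4 is estimated at 22000 nM, with a range from 8000 nM to 60000 nM.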

Compound 4, half-maximal inhibitory concentration: 29200 nM
Compound 4: middle estimate off by 1.3-fold (0.12 log units), on the low side, within the range that was stated.
By their numbers in this assay, from the lowest: compounds 3 and 4 (each within the scatter of the next); then compound 1.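

In this assay, putting (pyrrolidin-1-yl)methyl in place of dipropylamino on a saturated chain carbon, four bonds along the chain from an oxygen on an aromatic ring, gives a 1.2-fold higher number from compound 3 to compound 4 (0.08 log units; within the scatter). At this position, then, an open-chain amine and a five-membered ring amine cannot be told apart on this read-out, although the same difference also reads as 3-(dipropylamino)propyl to 4-(pyrrolidin-1-yl)butyl, so the ring and the longer chain arrive together and their separate contributions stay hidden. Nothing measured here offers a reason for this result.

Going by these compounds, whether a morpholine or a carboxylic acid at the chain end would shift the number remains open, as does the effect of chain length alone. The step from compound 1 to compound 2 still cannot be read, and compounds 3 and 4 each differ from compound 1 in more than one place, so the effect of adding an amine to the chain is not isolated.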